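This account rests on a few compounds, and the source may have more. Where it says the series, first, only, none or still open, it means among the compounds named here.

Values in a functional assay on PC-3 cells (Homo sapiens) for antiproliferative activity, read by MTT assay, with a stated time of 24 h (a higher number here means a weaker inhibitor, a lower number a stronger inhibitor), follow, each one a limit and not a number:

Compound 1 (`COc1ccc(-c2noc(-c3ccncc3)n2)cc1OC1CCCC1`) gives > 1000000 nM
Compound 2 (`COc1ccc(-c2noc(C3CCNCC3)n2)cc1OC1CCCC1`) gives > 1000000 nM
Compound 3 (`COc1ccc(-c2noc(-c3ccc(F)cc3)n2)cc1OC1CCCC1`) gives > 1000000 nM

Compound 3 stands only at a limit, with the whole series at the limit of > 1000000 nM in this assay, at which 3 of the 3 values shown sit, and no number to work from. Compound 4 (`COc1ccc(-c2noc(-c3ccc(Cl)cc3)n2)cc1OC1CCCC1`) differs from compound 3 by chloro in place of fluoro on an aromatic carbon, para to a large group (chloro in place of fluoro on an aromatic carbon). Going by the values given here, two measured steps bear on it (a step that the two limits leave unreadable from compound 1 to compound 3) and (a step that the two limits leave unreadable from compound 2 to compound 3) and neither has a readable size. No step beyond the scatter is therefore expected in this assay for this exchange. The estimate means a number no higher from compound 3 to compound 4 (the limit leaves the size open) as the expected step. For compound 4 the estimate is 1000000 nM with an expected range from 200000 nM to 2000000 nM and a good chance of another limit in place of a number.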

Compound 4, half-maximal inhibitory concentration: > 1000000 nM
Compound 4: a limit, no number; the forecaster's own chance of this, stated with the estimate: 80%; the middle value sits exactly at the limit.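

No step from compound 1, compound 2 or compound 3 to compound 4 can be read in this assay, where every result is a limit: the limit of > 1000000 nM in this assay, at which 4 of the 4 values shown sit.

The compounds shown leave open how any of these groups ranks against another in this assay.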